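The source may hold more compounds than are shown below. What is called first, only, known or untested is meant among the compounds shown, and "the series" means these compounds.

Measured so far:
compound 1 `C=CCSc1nncc2cnc(CCC)n12`, > 48000 nM in a functional assay for inhibition, with Homo sapiens as the target; a lower number here means a stronger inhibitor, a higher number a weaker inhibitor
compound 2 `C=CCSc1nncc2cnc(C)n12`, 61000 nM

Compound 1 returns only a limit of this assay, (the limit of > 48000 nM in this assay, at which 1 of the 2 values shown sits), and not a number. Among the measured compounds shown here, compound 2 gives 61000 nM, the one number in the set, so it stands alone with nothing to rank it against. The step that the limit leaves unreadable from compound 1 to compound 2 cannot be read because of the limit on compound 1.

Compound 3 `C=CCSc1nncc2cnc(-c3ccccc3)n12` is not yet measured. It differs from compound 2 by phenyl in place of methyl on an aromatic carbon. For the measured compounds named here, the only measured step touches a saturated chain on the same aromatic carbon and its size is hidden by the limit, so no measured step gives a direction for a phenyl at this place. Compound 2 already sits at a weak level, and the expectation for compound 3 is therefore set near it with wide bounds: the expected step of a 1.2-fold lower number from compound 2 to compound 3 (0.09 log units; within the scatter), giving an estimated 50000 nM for compound 3, in the range 15000 nM to 150000 nM, with a fair chance that only a limit is returned.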

Compound 3, half-maximal inhibitory concentration: > 48000 nM
Compound 3 gave a limit, no number (the forecaster's own chance of this, stated with the estimate: 50%); the middle value does not contradict the limit.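

Compound 3 returns a limit and not a number, so no step from compound 1 or compound 2 to compound 3 can be read: the limit of > 48000 nM in this assay, at which 2 of the 3 values shown sit.

The compounds shown leave open whether methyl, propyl and phenyl on this aromatic carbon differ at all in this assay.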